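Methoxy to isopropoxy: expected shift in antagonist potency

The source may report more compounds than this note shows. Statements on the series, on what has been measured and on what is new or still open speak of the compounds shown alone.

Within the data shown here, compound 2 `COc1ncc(-c2nc(C(F)(F)F)sc2N2CCN(C(=O)Cn3nc(C)nc3C)[C@H](C)C2)cn1` gives 25 nM in a functional assay on CHO-K1 cells for antagonist activity at C-X-C chemokine receptor type 3 (Homo sapiens), read by FLIPR, with a stated time of 10 min (on this read-out lower numbers stand for stronger inhibition and higher numbers for weaker inhibition), the highest of the two numbers so far; compound 1 `CCOc1ncc(-c2nc(C(F)(F)F)sc2N2CCN(C(=O)Cn3nc(C)nc3C)[C@H](C)C2)cn1` gives 7 nM. Among the measured compounds shown here, the only step measured, a 3.6-fold higher number from compound 1 to compound 2 (0.55 log units; beyond the scatter), concerns the same position. Compound 3 `Cc1nc(C)n(CC(=O)N2CCN(c3sc(C(F)(F)F)nc3-c3cnc(OC(C)C)nc3)C[C@H]2C)n1` differs from compound 2 by isopropyl in place of methyl on an oxygen on an aromatic ring, which runs opposite to that step and enlarges the group further, so a lower number beyond the scatter is expected in this assay, roughly the size of the measured step or somewhat more. Compound 3 is estimated at 5 nM, range 1.5 nM to 15 nM, an expected step of a 5.0-fold lower number from compound 2 to compound 3 (0.70 log units; beyond the scatter).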

Compound 3, half-maximal inhibitory concentration: 3.4 nM
For compound 3 the middle estimate is 1.5-fold (0.17 log units) above the measured one; measured number inside the range.
By their numbers in this assay, from the lowest: compound 3; then compound 1; then compound 2.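

Isopropyl on this oxygen extends the gain seen with ethoxy: a 7.4-fold lower number from compound 2 to compound 3 (0.87 log units; beyond the scatter) in this assay is larger than the step measured for the smaller change. Branching adds to that gain, with a 2.1-fold lower number from compound 1 to compound 3 (0.31 log units; beyond the scatter) still printed as beyond the scatter, so across compounds 1, 2 and 3 the number falls as the group on oxygen grows, and no compound here goes against this. Nothing available explains this trend.

From the compounds shown here alone, it remains open whether a straight propyl or a tert-butyl on this oxygen would continue the trend. Also open, going by these compounds, is how a terminal hydroxyl or an amine on the chain would read.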